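Solubility notes: triazole for piperazine on compound 2

A few compounds are considered here, and "the series" means these few. Any claim that something is new, unique, unknown or untested is made for them only; others in the source may bear on it.

The series shares one core; compound 1 `O=S(=O)(Nc1ccncn1)c1ccc2c(c1)OCC[C@@H]2c1ccc(C(F)(F)F)cc1-c1ccc(F)cn1`, compound 2 `O=S(=O)(Nc1nccs1)c1ccc2c(c1)OCC[C@@H]2c1ccc(C(F)(F)F)cc1N1CCNCC1` and compound 3 `Cn1nccc1-c1cc(C(F)(F)F)ccc1[C@H]1CCOc2cc(S(=O)(=O)Nc3cccnn3)ccc21` have been measured in a physicochemical assay for solubility; on this read-out lower numbers stand for lower solubility and higher numbers for higher solubility. Compound 1 gives 181000 nM, compound 2 gives 288000 nM and compound 3 gives 915000 nM. Compound 2 thus stands second highest of the three numbers, near compound 1 within the scatter and clearly under compound 3.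

Compound 4 `O=S(=O)(Nc1nccs1)c1ccc2c(c1)OCC[C@@H]2c1ccc(C(F)(F)F)cc1-n1ccnn1` is not yet measured. It differs from compound 2 in one place: 1H-1,2,3-triazol-1-yl in place of piperazin-1-yl on an aromatic carbon.

Going by the values given here, no measured pair shows this change, so the step is expected, not known. A small downward step, near the edge of the scatter, is expected from compound 2 to compound 4, a 1.9-fold lower number from compound 2 to compound 4 (0.28 log units; within the scatter). Compound 4 is therefore estimated at 150000 nM in this assay, with a range of 50000 nM to 450000 nM.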

Compound 4, solubility: 171000 nM
Compound 4: middle estimate off by 1.1-fold (0.06 log units), on the low side; the measured number falls inside the stated range.
By their numbers in this assay, from the lowest: compounds 4, 1 and 2 (each within the scatter of the next); then compound 3.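

In this assay, this position on an aromatic carbon, ortho to a large group, now has its first one-place comparison: 1H-1,2,3-triazol-1-yl in place of piperazin-1-yl gives a 1.7-fold lower number from compound 2 to compound 4 (0.23 log units; within the scatter). This single pair shows that an aromatic ring with 0 hydrogen-bond donors can replace a non-aromatic ring with 1 hydrogen-bond donor here with a step inside the scatter.

On these data alone, whether a carboxylic acid or an amine on a longer chain at this position would give a step beyond the scatter stays open. No measurement shown bears on a reason for the step.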